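The source may report more compounds than this note shows. Statements on the series, on what has been measured and on what is new or still open speak of the compounds shown alone.

Compound 1 `O=c1[nH]c(=O)n(CCC(CO)CO)cc1-c1cccs1` has in a functional assay on SW-620 cells (Homo sapiens) for antiproliferative activity, read by MTT assay, with a stated time of 72 h (a higher number here means a weaker inhibitor, a lower number a stronger inhibitor), a value of > 100000 nM, which is a limit of the assay and not a number. Compound 2 `CCCCCc1ccc(C#Cc2cn(CCC(COC(C)=O)COC(C)=O)c(=O)n(C(=O)c3ccccc3)c2=O)cc1` likewise gives > 100000 nM, again a limit. Compound 3 `CC(=O)OCC(CCn1cc(C#CCc2ccccc2)c(=O)n(C(=O)c2ccccc2)c1=O)COC(C)=O` gives 36400 nM.

Compound 3 thus stands as the only one of the three with a measured number in this assay; the other two values are limits. Within the data shown here, the one measured step, an at least 2.7-fold lower number from compound 2 to compound 3 (0.43 log units; beyond the scatter), is the only comparison that touches the group on the triple bond. Its size is bounded on one side by the limit of > 100000 nM in this assay, at which 2 of the 3 values shown sit, so only its lower end is known.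

Compound 4 `CCCCCCCCC#Cc1cn(CCC(COC(C)=O)COC(C)=O)c(=O)n(C(=O)c2ccccc2)c1=O` differs from compound 3 by heptyl in place of phenyl on a saturated chain carbon bound to a triple-bonded carbon. The step from compound 2 to compound 3 concerns the same position but a different pair of groups, so it bears on this change only indirectly. Compound 4 is therefore estimated at 45000 nM, within 12000 nM to 150000 nM, the expected step of a 1.2-fold higher number from compound 3 to compound 4 (0.09 log units; within the scatter) being small and possibly within the scatter.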

Compound 4, half-maximal inhibitory concentration: 65800 nM
Estimate against measurement, compound 4: 1.5-fold (0.17 log units) below, and the stated range covers the measured number.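

In this assay, phenyl and heptyl on a saturated chain carbon bound to a triple-bonded carbon can now be compared directly, and the step, a 1.8-fold higher number from compound 3 to compound 4 (0.26 log units; within the scatter), does not separate them. Thus compound 4, whose heptyl group has no ring, also gives a measured number, as does compound 3 with its phenyl. The comparison with the limit of compound 2 gives an at least 1.5-fold lower number from compound 2 to compound 4 (0.18 log units; that floor lies within the scatter), so only a floor is known, and that floor does not clear the scatter: the limit of > 100000 nM in this assay, at which 2 of the 4 values shown sit.

The compounds shown leave open whether a longer chain at this place, or a chain ending in an amine or a carboxylic acid, would shift the number beyond the scatter. They also leave open whether either group would give the same result on the shared core without the benzoyl group.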